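Carbonyl substituent series: pyrrole to indole step

The source may report more compounds than this note shows. Statements on the series, on what has been measured and on what is new or still open speak of the compounds shown alone.

Measured so far in a functional assay on NCI-H1299 cells (Homo sapiens) for antiproliferative activity, read by XTT assay, with a stated time of 72 h; on this read-out higher numbers stand for weaker inhibition and lower numbers for stronger inhibition:
compound 1 `COc1ccc(-c2cc3ccccc3nc2/C=C/C(=O)c2ccc(O)cc2)cc1` gives 8970 nM.
compound 2 `COc1ccc(-c2cc3ccccc3nc2/C=C/C(=O)c2cccs2)cc1` gives 720 nM.
compound 3 `COc1ccc(-c2cc3ccccc3nc2/C=C/C(=O)c2ccc[nH]2)cc1` returns only an assay limit, > 10000 nM.

Compound 3 thus stands at the limit, not at a number. Its measured steps are an at least 1.1-fold higher number from compound 1 to compound 3 (0.04 log units; that floor lies within the scatter), within the scatter, and an at least 13-fold higher number from compound 2 to compound 3 (1.14 log units; beyond the scatter), a large rise. The change now considered is 1H-indol-3-yl in place of 1H-pyrrol-2-yl on a carbonyl carbon, giving compound 4 `COc1ccc(-c2cc3ccccc3nc2/C=C/C(=O)c2c[nH]c3ccccc23)cc1`. For the measured compounds named here, no measured step exchanges 1H-pyrrol-2-yl for 1H-indol-3-yl, so the bearing of the measured steps is indirect: a 12-fold lower number from compound 1 to compound 2 (1.10 log units; beyond the scatter) and an at least 13-fold higher number from compound 2 to compound 3 (1.14 log units; beyond the scatter) show the group on the carbonyl carbon shifts the read-out widely. A moderate downward step is expected, an at least 3.3-fold lower number from compound 3 to compound 4 (0.52 log units; beyond the scatter). Compound 4 is estimated at 3000 nM, expected between 800 nM and 10000 nM.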

Compound 4, half-maximal inhibitory concentration: > 10000 nM
Compound 4 was reported as a limit; the forecaster's own chance of this, stated with the estimate: 25%; middle value at least 3.3-fold (0.52 log units) from the limit.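

In this assay the 1H-indol-3-yl group, with the six-membered aromatic ring of carbon only that 1H-pyrrol-2-yl lacks, also yields only an assay limit, and the step between these two limits cannot be read. Thiophen-2-yl keeps its lead with an at least 13-fold higher number from compound 2 to compound 4 (1.14 log units; beyond the scatter) and 4-hydroxyphenyl gives an at least 1.1-fold higher number from compound 1 to compound 4 (0.04 log units; that floor lies within the scatter) as a floor only. Compound 3 and compound 4 now share one limit: the limit of > 10000 nM in this assay, at which 2 of the 4 values shown sit.

As far as these compounds go, how far beyond that limit compound 3 and compound 4 lie stays open. Also open, from the compounds shown here alone, is how a furan-2-yl or 4-aminophenyl group on the carbonyl carbon would compare with thiophen-2-yl.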